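The compounds below may be only part of what the source reports. "The series", "measured", "known", "first", "only" and "open" are said of these compounds alone.

Of the compounds shown here, three built on one shared core have been measured. Compound 1 `CC1(C)CC(NC(=O)NCc2ccccc2)c2cc(Cl)ccc2O1` gives 66000 nM in a functional assay on U-373MG ATCC cells (Homo sapiens) for inhibition, read by MTT assay, with a stated time of 72 h; a lower number here means a stronger inhibitor, a higher number a weaker inhibitor. Compound 2 `CC(C)NC(=O)NC1CC(C)(C)Oc2ccc(Cl)cc21` gives 62000 nM in this assay, and compound 3 `CC1(C)CC(NC(=O)Nc2ccccc2)c2cc(Cl)ccc2O1` gives 68000 nM in this assay. The three swaps on the amide-type nitrogen move little: a 1.1-fold lower number from compound 1 to compound 2 (0.03 log units; within the scatter), a 1.0-fold higher number from compound 1 to compound 3 (0.01 log units; within the scatter) and a 1.1-fold higher number from compound 2 to compound 3 (0.04 log units; within the scatter). Compound 3 therefore sits alongside compounds 1 and 2, its values separated from both by less than the scatter.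

Compound 4 `CC1(C)CC(NC(=O)Nc2cccc(Cl)c2)c2cc(Cl)ccc2O1` departs from compound 3 by a single change: chloro in place of hydrogen on an aromatic carbon. Going by the values given here, none of the measured steps touches an aromatic carbon of this ring; they all exchange the whole group on the amide-type nitrogen, and each stayed within the scatter. Among the compounds with values here, the data hold no step that probes a chloro added to the ring, so there is no basis for expecting a shift in this assay beyond the scatter. The step of no change at the digits printed from compound 3 to compound 4 (within the scatter) is thus estimated as essentially flat. Compound 4 is expected to give about 68000 nM in this assay, within the range 30000 nM to 150000 nM.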

Compound 4, half-maximal inhibitory concentration: 21000 nM
For compound 4 the middle estimate is 3.2-fold (0.51 log units) above the measured one, outside the stated range (below it).
By their numbers in this assay, from the lowest: compound 4; then compounds 2, 1 and 3 (each within the scatter of the next).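

In this assay the change from phenyl to 3-chlorophenyl gives a 3.2-fold lower number from compound 3 to compound 4 (0.51 log units; beyond the scatter) and is thus a step beyond the scatter, while the earlier exchanges of the whole group on the amide-type nitrogen all stayed within it. The 3-chlorophenyl group also separates from the other two groups on that nitrogen, with a 3.0-fold lower number from compound 2 to compound 4 (0.47 log units; beyond the scatter) and a 3.1-fold lower number from compound 1 to compound 4 (0.50 log units; beyond the scatter), so a single chloro on this aromatic carbon registers where the choice among isopropyl, benzyl and phenyl did not. Nothing in the data at hand accounts for this shift.

From the compounds shown here alone, whether a chloro elsewhere on this ring, or a methoxy, a nitrile or an amine on the same carbon, would give a like step remains open. So does whether the same chloro on the benzyl group of compound 1 would repeat it.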